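The compounds below may be only part of what the source reports. "The series", "measured", "known", "first", "only" and "open" are said of these compounds alone.

Compound 1 `COc1ccc(-c2c(C)nc3c(NCc4ccc(C(N)=O)cc4)cc(C)cn23)cc1OC` and compound 2 `COc1ccc(-c2c(C)nc3c(NCc4cccnc4)cc(C)cn23)cc1OC` are built on one core, while compound 3 `COc1ccc(-c2c(C)nc3c(NCc4ccc(C(N)=O)cc4)nc(C)cn23)cc1OC` and the as yet unmeasured compound 4 `COc1ccc(-c2c(C)nc3c(NCc4cccnc4)nc(C)cn23)cc1OC` are built on another; the difference between the two cores is not broken down here. In a physicochemical assay for lipophilicity, at pH 7.4 (on this read-out lower numbers stand for lower lipophilicity and higher numbers for higher lipophilicity), compound 1 gives 4.3. In this assay compound 2 gives 4.9. The change that separates these two is pyridin-3-yl in place of 4-carbamoylphenyl on a saturated chain carbon bound to a nitrogen on an aromatic ring, and it produced a step of a number 0.60 log units higher from compound 1 to compound 2 (beyond the scatter). In this assay compound 3 gives 3.9, the lowest of the three numbers, with compound 1 the nearest to it and compound 2 the furthest. Compound 4 differs from compound 3 by the same change, (pyridin-3-yl in place of 4-carbamoylphenyl on a saturated chain carbon bound to a nitrogen on an aromatic ring), at a place described in identical words. Because the earlier pair moved by a number 0.60 log units higher from compound 1 to compound 2 (beyond the scatter), a step of similar size is expected on the second core, estimated at a number 0.60 log units higher from compound 3 to compound 4 (beyond the scatter). Compound 4 is therefore expected to give about 4.5 in this assay, most likely falling between 4.2 and 4.8.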

Compound 4, distribution coefficient: 4.5
Estimate against measurement, compound 4: no gap at the digits printed; the measured number falls inside the stated range.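

In this assay, putting pyridin-3-yl in place of 4-carbamoylphenyl on a saturated chain carbon bound to a nitrogen on an aromatic ring gave a number 0.60 log units higher from compound 3 to compound 4 (beyond the scatter), a step that matches a number 0.60 log units higher from compound 1 to compound 2 (beyond the scatter), so in these two pairs the change carried from one core to the other with its size intact. This shows only that the step was the same on the two cores shown; two pairs that share a single change do not establish a rule for other replacements, for other cores or for other read-outs. Nothing presented here explains why the two steps agree.

The compounds shown leave open whether other groups at this place, such as a morpholine, a carboxylic acid or a longer chain in place of the (pyridin-3-yl)methyl, would also give matching steps on the two cores. They also leave open whether a change at any other place on these cores would carry across in the same way.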